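Swapping a Methyl for Trifluoromethyl on the Benzyl Arm

The source may report more compounds than this note shows. Statements on the series, on what has been measured and on what is new or still open speak of the compounds shown alone.

Measured compounds:
compound 1 `Cc1cc(Nc2ccn(Cc3nc(C)c4ccccc4n3)n2)n2nc(SCc3ccc(Br)cc3)nc2n1` gives 960 nM in a functional assay on MGC-803 cells (Homo sapiens) for inhibition, read by MTT assay, with a stated time of 72 h; a higher number here means a weaker inhibitor, a lower number a stronger inhibitor
compound 2 `Cc1ccc(Cn2ccc(Nc3cc(C)nc4nc(SCc5ccc(Br)cc5)nn34)n2)cc1` gives 7420 nM in this assay

Compound 2 has the higher of the two numbers shown, and the step of a 7.7-fold higher number from compound 1 to compound 2 (0.89 log units; beyond the scatter) separates it from compound 1. Compound 3 `Cc1cc(Nc2ccn(Cc3ccc(C(F)(F)F)cc3)n2)n2nc(SCc3ccc(Br)cc3)nc2n1` is not yet measured. It differs from compound 2 in one place, where (trifluoromethyl in place of methyl on an aromatic carbon). Among the measured compounds shown here, the only measured step, a 7.7-fold higher number from compound 1 to compound 2 (0.89 log units; beyond the scatter), exchanges the whole ring attached to the saturated chain carbon and so says nothing about changing one group on that ring; no measured step bears directly on this change. With no guide from the data, a step of a 1.1-fold lower number from compound 2 to compound 3 (0.06 log units; within the scatter) is expected, which would lie within the scatter, in no settled direction. Compound 3 is therefore estimated at 6500 nM, with a range from 2000 nM to 20000 nM.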

Compound 3, half-maximal inhibitory concentration: 2590 nM
The estimate for compound 3 lay 2.5-fold (0.40 log units) above the measured number; measured number inside the range.
By their numbers in this assay, from the lowest: compound 1; then compound 3; then compound 2.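

In this assay the exchange of methyl for trifluoromethyl on the phenyl ring gives a 2.9-fold lower number from compound 2 to compound 3 (0.46 log units; beyond the scatter) and so shows that one small group at this place can move the number, which the earlier exchange of a whole ring could not show. The 4-(trifluoromethyl)phenyl arm still falls short of the 4-methylquinazolin-2-yl arm, with a 2.7-fold higher number from compound 1 to compound 3 (0.43 log units; beyond the scatter) leaving compound 1 with the lowest number of the three. Nothing measured here explains why compound 3 gives a lower number than compound 2.

On these data alone, whether the gain is tied to fluorine or would also appear with a chlorine atom, a methoxy group or an amine at this place remains open. So does whether a carboxylic acid or a longer chain there would bring the number closer to that of compound 1.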